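Thiazole ether series: changing the acid head of compound 2

This account rests on a few compounds, and the source may have more. Where it says the series, first, only, none or still open, it means among the compounds named here.

In an assay on CHO cells for agonist activity at Free fatty acid receptor 1 (Homo sapiens), read by FLIPR (on this read-out higher numbers stand for an effect only at larger amounts of compound and lower numbers for an effect already at smaller amounts), compound 2 `Cc1nc(-c2ccccc2)sc1COc1ccc(S(=O)(=O)CC(=O)O)cc1` gives 370 nM, the highest of the two numbers recorded here. Its nearest neighbour is compound 3 `Cc1nc(-c2ccc(F)cc2)sc1COc1ccc(S(=O)(=O)CC(=O)O)cc1`, which in this assay gives 253 nM; the change between them is a 1.5-fold lower number from compound 2 to compound 3 (0.17 log units; within the scatter). Compound 1 `O=C(O)COc1ccc(OCc2csc(-c3ccccc3)n2)cc1F` yields in this assay only a limit, > 10000 nM (the limit of > 10000 nM in this assay, at which 1 of the 3 values shown sits).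

The step to compound 4 `Cc1nc(-c2ccccc2)sc1COc1ccc(CCC(=O)O)cc1` alters the acid head: 2-carboxyethyl in place of (carboxymethyl)sulfonyl on an aromatic carbon. For the measured compounds named here, none of the measured steps touches this part of the molecule; the single measured step, from compound 2 to compound 3, concerns the distal ring and sits within the scatter. Going by the values given here, compound 1 carries yet another acid head and differs elsewhere as well, so its limit and the number of compound 2 show only that the two values differ, and no step between them can be counted. The expectation for compound 4 in this assay therefore rests on the structural change alone and carries wide bounds. Compound 4 is expected at 150 nM, between 40 nM and 600 nM. This estimate means a 2.5-fold lower number from compound 2 to compound 4 (0.39 log units; beyond the scatter).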

Compound 4, half-maximal effective concentration: 590 nM
The estimate for compound 4 lay 3.9-fold (0.59 log units) below the measured number; low and high end bracket the measured number.
By their numbers in this assay, from the lowest: compounds 3, 2 and 4 (each within the scatter of the next, the first and the last beyond it). At a limit, above all of these: compound 1.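

For the compounds shown here, the first measured change at the acid head, on an aromatic carbon para to a large group, gives in this assay a 1.6-fold higher number from compound 2 to compound 4 (0.20 log units; within the scatter), so the two heads cannot be told apart on this read-out. The (carboxymethyl)sulfonyl group, with 7 heavy atoms and 3 hydrogen-bond acceptors, can thus give way to the 2-carboxyethyl group, with 5 heavy atoms and 1 hydrogen-bond acceptor, without a step beyond the scatter, and in this pair the sulfonyl is not needed to keep the number in this range. Nothing measured here gives a reason for this result.

The compounds shown leave open how a head without a carboxylic acid, such as a primary amide or a tetrazole, or a longer chain ending in a carboxylic acid, would read at this position. They also leave open how the fluoro group of compound 3 would read when combined with the 2-carboxyethyl head of compound 4.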